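The source may report more compounds than this note shows. Statements on the series, on what has been measured and on what is new or still open speak of the compounds shown alone.

Measured in a functional assay on HeLa cells (Homo sapiens) for antiproliferative activity, read by MTT assay, with a stated time of 72 h; a higher number here means a weaker inhibitor, a lower number a stronger inhibitor
compound 1 `COc1ccc(NC(=S)Nc2nc(C(=O)NCCCc3ccccc3)cs2)cc1` gives 57500 nM
compound 2 `COc1ccc(-c2c(CN3CCCCC3)nc3scc(C(=O)O)n23)cc1` gives 47400 nM
compound 3 `CC(=O)NNC(=O)c1csc2ncc(-c3ccc(C)cc3)n12` gives 74200 nM

Compound 3 (74200 nM) lies within the scatter of both compound 1 (57500 nM) and compound 2 (47400 nM), so these three values give no ranking. The next compound to be tested is compound 4 `CCC(=O)NNC(=O)c1csc2ncc(-c3ccc(C)cc3)n12` and it departs from compound 3 by one change. That change is methyl in place of hydrogen on a saturated chain carbon bound to a carbonyl carbon and in words it is methyl in place of hydrogen on a saturated chain carbon bound to a carbonyl carbon, which turns acetyl into propanoyl.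

Within the data shown here, no two measured compounds differ in one place only, so the series offers no direct measure of this kind of change. Among the measured compounds shown here, the expectation therefore starts from compound 3 at 74200 nM as the only measured compound that shares the rest of the structure. No step beyond the scatter is expected in this assay and no direction is favoured. The expected step is a 1.1-fold lower number from compound 3 to compound 4 (0.03 log units; within the scatter) and it remains an estimate until the measurement is made. For compound 4 the estimated value is 70000 nM with an expected range from 38000 nM to 100000 nM in this read-out.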

Compound 4, half-maximal inhibitory concentration: 13000 nM
For compound 4 the middle estimate is 5.4-fold (0.73 log units) above the measured one; the measured number lies below the stated range.
By their numbers in this assay, from the lowest: compound 4; then compounds 2, 1 and 3 (each within the scatter of the next).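

Turning acetyl into propanoyl, with methyl in place of hydrogen on a saturated chain carbon bound to a carbonyl carbon, gives the only readable step in the series: in this assay there is a 5.7-fold lower number from compound 3 to compound 4 (0.76 log units; beyond the scatter), a modest change but one beyond the scatter. Among these compounds, this position therefore responds to the addition of a single methyl, something the earlier compounds could not show, as their values lie within the scatter of one another and no two of them differ in one place only. No measurement at hand bears on the reason for this step.

Whether the number keeps falling with a longer chain such as butanoyl, or shifts differently with a benzoyl group or an amine on the same chain carbon, stays open from the compounds shown. Among the compounds shown here, with only this one pair, it also stays open whether the acetyl to propanoyl change gives a step of similar size when the rest of the structure carries other groups.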